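The compounds below may be only part of what the source reports. "The series", "measured", "known", "first", "only" and "open" are said of these compounds alone.

The measured compounds, with their largest response in an assay on HEK293 cells for agonist activity at Bile acid receptor (Homo sapiens); on this read-out higher numbers stand for larger maximal responses and lower numbers for smaller maximal responses:
compound 1, `O=C(O)CNC(=O)c1ccc(C2CC2c2ccc(OCc3c(-c4c(Cl)cccc4Cl)noc3C3CC3)cc2Cl)cc1`, gives 58%;
compound 2, `CCO[C@]1(c2ccc(OCc3c(-c4c(Cl)cccc4Cl)noc3C3CC3)cc2Cl)C[C@H](c2cccc(C(=O)O)c2)C1`, gives 89%;
compound 3, `O=C(O)c1cccc([C@H]2C[C@@H](c3ccc(OCc4c(-c5c(Cl)cccc5Cl)noc4C4CC4)cc3Cl)C2)c1`, gives 88%.

Among these three, compound 1 stands lowest: compound 3 lies above it, and compound 2 lies further above it still, both gaps beyond the scatter. For the measured compounds named here, the one single-point step that has been measured, a number 1 percentage points lower from compound 2 to compound 3 (within the scatter), concerns the saturated ring of compound 2 and says nothing about the acid-bearing end that compound 1 carries.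

Compound 4, `CS(=O)(=O)NC(=O)c1ccc(C2CC2c2ccc(OCc3c(-c4c(Cl)cccc4Cl)noc3C3CC3)cc2Cl)cc1`, differs from compound 1 at that end only: methylsulfonyl in place of carboxymethyl on an amide-type nitrogen. Going by the values given here, no measured pair shows this exchange or anything close to it, so the step from compound 1 to compound 4 cannot be read from a precedent. Among the compounds with values here, the only anchor is compound 1 itself, and the remaining data show merely that the shared core tolerates a change at the saturated ring without a shift beyond the scatter. Under that uncertainty the expected step is a number 2 percentage points higher from compound 1 to compound 4 (within the scatter), with no direction favoured beyond the scatter. Compound 4 is therefore estimated at 60% in this assay, within a range from 38% to 82%.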

Compound 4, largest response reached (reported as efficacy), in percent of the reference or control that the assay uses: 88%
For compound 4 the middle estimate is 28 percentage points below the measured one, and the stated range ends below it.
By their numbers in this assay, from the lowest: compound 1; then compounds 3, 4 and 2 (each within the scatter of the next).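

In this assay, the group on the amide-type nitrogen proves to matter: methylsulfonyl in place of carboxymethyl gives a number 30 percentage points higher from compound 1 to compound 4 (beyond the scatter) on an otherwise unchanged structure. For the compounds shown here, the earlier compounds showed only that a change at the saturated ring, from compound 2 to compound 3, could pass without a shift beyond the scatter, and they held no information about this position; the new pair shows that the maximal response here responds to the exchange of one group of 4 heavy atoms for another of the same count. Nothing on hand explains why this exchange has such an effect.

The compounds shown leave open whether the higher response belongs to the methylsulfonyl group itself or follows from the loss of carboxymethyl, a question that a group such as acetyl or ethylsulfonyl on the same nitrogen would help to settle. As far as these compounds go, it also remains open whether the same exchange would have a comparable effect on the structures of compound 2 and compound 3, which differ from compound 1 in more than one place.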